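Lengthening the amine chains on the methyl compound

A few compounds are considered here, and "the series" means these few. Any claim that something is new, unique, unknown or untested is made for them only; others in the source may bear on it.

Among the measured compounds shown here, in a functional assay (aorta) with Rattus norvegicus as the target (a higher number here means a weaker inhibitor, a lower number a stronger inhibitor), compound 1 `CCN(CC)CCCOc1ccc(S(=O)(=O)c2c(C)cn3ccccc23)cc1` gives 3390 nM, the highest of the three numbers so far. Compound 2 `CCN(CC)CCCOc1ccc(S(=O)(=O)c2c(C(C)C)cn3ccccc23)cc1` gives 228 nM, and compound 3 `COc1ccc(CN(C)CCCOc2ccc(S(=O)(=O)c3c(C4CC4)cn4ccccc34)cc2)cc1OC` gives 4.7 nM, the lowest of the three.

Compound 4 `CCCCN(CCCC)CCCOc1ccc(S(=O)(=O)c2c(C)cn3ccccc23)cc1` keeps the core of compound 1 and differs only at the amine: dibutylamino in place of diethylamino on a saturated chain carbon, three bonds along the chain from an oxygen on an aromatic ring.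

For the measured compounds named here, only one measured step bears on this, and only indirectly: a 15-fold lower number from compound 1 to compound 2 (1.17 log units; beyond the scatter). It is large and beyond the scatter, but it is isopropyl in place of methyl on an aromatic carbon, not a change at the amine. Going by the values given here, no measured step changes the amine alone, so the size of that step cannot be carried over. Its direction, towards a lower number with the larger alkyl group, gives only a weak hint. A modest move towards a lower number is therefore expected in this assay, with the estimated step of a 2.3-fold lower number from compound 1 to compound 4 (0.35 log units; beyond the scatter). For compound 4 the estimate is 1500 nM, with an expected range of 400 nM to 5000 nM.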

Compound 4, half-maximal inhibitory concentration: 162 nM
Compound 4: middle estimate off by 9.3-fold (0.97 log units), on the high side, outside the stated range (below it).
By their numbers in this assay, from the lowest: compound 3; then compounds 4 and 2 (each within the scatter of the next); then compound 1.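

In this assay the amine end of the chain proves to be a position where a single change counts: dibutylamino in place of diethylamino gives a 21-fold lower number from compound 1 to compound 4 (1.32 log units; beyond the scatter), a large step beyond the scatter. Among the compounds shown here, the only earlier step, a 15-fold lower number from compound 1 to compound 2 (1.17 log units; beyond the scatter), lay on an aromatic carbon, so compound 1 now has two separate single changes, each lowering the number. No measurement at hand accounts for the step at the amine.

Open, going by these compounds, is whether dipropylamino or a cyclic amine such as piperidine, in place of diethylamino on the core of compound 1, would also lower the number. Also open, on these data alone, is whether dibutylamino on the core of compound 2 would add to the isopropyl step, since the two changes are seen here only separately.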